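A methoxy swap in a series at its limit

The compounds below may be only part of what the source reports. "The series", "measured", "known", "first", "only" and "open" are said of these compounds alone.

- compound 1 `Cc1cccc(-c2nc3cc(C)ccc3c(=O)[nH]2)c1`: > 50000 nM
- compound 2 `Cc1cccc(-c2nc3ccc(C)cc3c(=O)[nH]2)c1`: > 50000 nM
- compound 3 `Cc1ccc2nc(-c3cccc4ccccc34)[nH]c(=O)c2c1`: > 50000 nM

All three results come from a functional assay on T47D cells (Homo sapiens) for cytotoxicity, read by MTT assay, with a stated time of 2 days (on this read-out higher numbers stand for weaker inhibition and lower numbers for stronger inhibition), and none of them is an exact number. Compound 2 gives > 50000 nM, which is a limit of the assay. The same holds across the set, as the record shows (the limit of > 50000 nM in this assay, at which 3 of the 3 values shown sit).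

Compound 4 `COc1cccc(-c2nc3ccc(C)cc3c(=O)[nH]2)c1` differs from compound 2 in one place: methoxy in place of methyl on an aromatic carbon. Methoxy stands in place of methyl on an aromatic carbon of a six-membered aromatic ring of carbon only, meta to a large group.

Among the measured compounds shown here, no two measured compounds differ in one place only, so the data hold no direct guide to the size of such a step. With compound 2 at the limit > 50000 nM, no step beyond the usual scatter is expected in this assay, and compound 4 may well report a limit too. The expected step is an at least 1.1-fold lower number from compound 2 to compound 4 (0.04 log units; that floor lies within the scatter). Compound 4 is estimated at 45000 nM. The expected range for compound 4 runs from 15000 nM to 80000 nM.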

Compound 4, half-maximal inhibitory concentration: > 50000 nM
Compound 4 was reported as a limit; the forecaster's own chance of this, stated with the estimate: 65%; middle value at least 1.1-fold (0.04 log units) away from the limit.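

Compound 4 gives > 50000 nM in this assay, which is a limit and not a number. Compound 2 sits at the same limit, so no step can be read between compound 2 and compound 4: the limit of > 50000 nM in this assay, at which 4 of the 4 values shown sit. The compounds shown leave open whether methoxy and methyl differ at all on these cells.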